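The compounds below may be only part of what the source reports. "The series", "measured", "known", "first", "only" and "open" are said of these compounds alone.

Measured compounds:
- compound 1 `O=C(c1cn[nH]c1)N1CCC(C(=O)N2N=CCC2c2ccccc2)CC1`: 2.1
- compound 2 `O=C(C1CCC1)N1N=CCC1c1ccccc1`: 4.7
- compound 3 `CC(C)(C)C(=O)N1N=CCC1c1cccc(F)c1`: 5.9

These three compounds share a core and were all measured in a physicochemical assay for lipophilicity, read by HPLC, measured as chromatographic lipophilicity, at pH 7.4; on this read-out lower numbers stand for lower lipophilicity and higher numbers for higher lipophilicity. Compound 1 gives 2.1, the lowest of the three numbers. Compound 3 gives 5.9, the highest. Compound 2, with 4.7, stands second highest: its nearest neighbour is compound 3, whose value lies above it by more than the usual scatter, and its furthest neighbour is compound 1, whose value lies far below it, again beyond the scatter.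

The step followed here goes from compound 2 to compound 4 `CC(C)C(=O)N1N=CCC1c1ccccc1`, which has not yet been measured in this assay. The change is small: isopropyl in place of cyclobutyl on a carbonyl carbon. The group that leaves and the group that enters are both made of carbon only, carry no hydrogen-bond donors or acceptors and no charge, so the count of heavy atoms falls by one and a four-membered ring is opened.

Going by the values given here, no measured pair in this set shows this exact change, so the size of the step can only be estimated. Removing one carbon is expected to lower the number a little, perhaps at the edge of the scatter. The estimated step from compound 2 to compound 4 is a number 0.40 log units lower from compound 2 to compound 4 (beyond the scatter). Compound 4 is therefore expected to give about 4.3, within a range from 3.8 to 4.8.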

Compound 4, distribution coefficient: 4.4
Beside the measured number, compound 4's estimate is 0.10 log units below it; the measured number falls inside the stated range.
By their numbers in this assay, from the lowest: compound 1; then compounds 4 and 2 (each within the scatter of the next); then compound 3.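

In this assay, going by these compounds alone, putting isopropyl in place of cyclobutyl on a carbonyl carbon gives a number 0.30 log units lower from compound 2 to compound 4 (within the scatter), the first direct reading of a single change in this set. At this place on the shared core, then, cyclobutyl, with 4 heavy atoms and a ring, and isopropyl, with 3 heavy atoms and no ring, cannot be told apart on this read-out, so in this one pair neither the ring nor the difference in heavy atoms leaves a mark larger than the usual scatter. No measurement on hand offers a reason for this result.

Compounds 1 and 3 each differ from compounds 2 and 4 in more than one place, so steps to them cannot be read, and this single pair cannot show how far the result extends to other carbon-only groups. It also leaves open what happens at the same carbonyl carbon with a longer chain such as n-butyl, or with a group that carries an amine or a carboxylic acid.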